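Adding dimethylamino to a weak hydroxamic acid

A few compounds are considered here, and "the series" means these few. Any claim that something is new, unique, unknown or untested is made for them only; others in the source may bear on it.

Compound 1 (`Cc1ccc(NC(=O)CN(CCCCCC(=O)NO)C(=O)c2cc(C)cc(C)c2)cc1`) gives 1270 nM
Compound 2 (`CC(C)(C(=O)NC1CCCCC1)N(CCCCCC(=O)NO)C(=O)c1ccccc1`) gives 295000 nM

Both numbers come from a functional assay on A2780 cells (Homo sapiens) for cytotoxicity, read by MTT assay, with a stated time of 72 h (on this read-out lower numbers stand for stronger inhibition and higher numbers for weaker inhibition), and together they are all that has been measured so far. Compound 2 stands at 295000 nM as the higher of the two numbers, and compound 1 at 1270 nM lies below it by far more than the usual scatter. These two compounds differ in more than one place, so their gap cannot be tied to any single group.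

Compound 3 (`CN(C)c1ccc(C(=O)N(CCCCCC(=O)NO)C(C)(C)C(=O)NC2CCCCC2)cc1`) differs from compound 2 in one place (dimethylamino in place of hydrogen on an aromatic carbon), with dimethylamino in place of hydrogen on an aromatic carbon, para to a large group, so that phenyl becomes 4-(dimethylamino)phenyl. For the measured compounds named here, no measured pair shows this change on its own, which leaves only a loose expectation. The direction rests on compound 2 at 295000 nM having the higher of the two numbers. The estimated step (a 2.3-fold lower number from compound 2 to compound 3 (0.36 log units; beyond the scatter)) is a modest one toward stronger inhibition in this assay and may not clear the scatter. Compound 3 is expected at 130000 nM with an estimated range from 25000 nM to 450000 nM around it.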

Compound 3, half-maximal inhibitory concentration: 68500 nM
Compound 3: middle estimate off by 1.9-fold (0.28 log units), on the high side; the range from low to high includes it.
By their numbers in this assay, from the lowest: compound 1; then compound 3; then compound 2.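

In this assay, placing dimethylamino in place of hydrogen on an aromatic carbon, para to a large group, gives a 4.3-fold lower number from compound 2 to compound 3 (0.63 log units; beyond the scatter), a modest step toward stronger inhibition that lies beyond the usual scatter. For the compounds shown here, this is the first gap that can be tied to a single group, since everything else in the structure stays the same across this pair, so this position on the ring does respond to substitution. Nothing at hand explains why this change lowers the number, so the step remains an observation without a stated cause.

A single pair cannot show whether the step belongs to dimethylamino itself or whether another group at the same place, such as methoxy, a primary amine or a carboxylic acid, would shift the number as far, or in the opposite direction. From the compounds shown here alone, it is also open whether 4-(dimethylamino)phenyl would bring a step of similar size on the core of compound 1, where the amide part and the aromatic ring differ from those of compound 2.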